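The source may hold more compounds than are shown below. What is called first, only, known or untested is meant among the compounds shown, and "the series" means these compounds.

Compound 1 `CC1CCCCN1C(=S)SCc1ccc(C(=O)Nc2ccccc2N)cc1` and compound 2 `N#Cc1ccc(N2CCN(C(=S)SCc3ccc(C(=O)Nc4ccccc4N)cc3)CC2)cc1` have the shared core and differ only in the group on the thiocarbonyl carbon. In a functional assay on A-375 cells (Homo sapiens) for antiproliferative activity, read by CCK-8 assay, with a stated time of 72 h, tested at 2 uM (a higher number here means a stronger effect of the compound at the concentration tested, a lower number a weaker effect), compound 1 gives 42.5%, and compound 2 gives 41.4%; these two numbers lie within the scatter of each other, so compound 1 stands level with compound 2 rather than apart from it. Compound 3 `CN(Cc1cccnc1)C(=S)SCc1ccc(C(=O)Nc2ccccc2N)cc1` has not been measured. It differs from compound 1 in one place: methyl((pyridin-3-yl)methyl)amino in place of 2-methylpiperidin-1-yl on a thiocarbonyl carbon. Among the compounds with values here, no measured pair here shows what such a change does, so no step beyond the scatter is expected a number 4.5 percentage points lower from compound 1 to compound 3 (within the scatter). Compound 3 is estimated at 38%, within 22% to 55%.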

Compound 3, a percentage reported as inhibition, at one concentration (the size of the read-out at that concentration, not a potency): 39.4%
For compound 3 the middle estimate is 1.4 percentage points below the measured one; measured number inside the range.
By their numbers in this assay, from the lowest: compounds 3, 2 and 1 (each within the scatter of the next).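

In this assay, methyl((pyridin-3-yl)methyl)amino in place of 2-methylpiperidin-1-yl on a thiocarbonyl carbon gives a number 3.1 percentage points lower from compound 1 to compound 3 (within the scatter) at this single concentration. This position therefore holds a six-membered aromatic ring with a hydrogen-bond acceptor as well as a six-membered non-aromatic ring, with no step beyond the scatter. No outside evidence bears on this result. Still open, from the compounds shown here alone, is whether any group on this carbon moves the number beyond the scatter, for instance morpholin-4-yl or a longer chain ending in a carboxylic acid.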